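A few compounds are considered here, and "the series" means these few. Any claim that something is new, unique, unknown or untested is made for them only; others in the source may bear on it.

Measured in a functional assay on BGC-823 cells (Homo sapiens) for antiproliferative activity, read by MTT assay, with a stated time of 24 h; on this read-out lower numbers stand for stronger inhibition and higher numbers for weaker inhibition:
- Compound 1 `O=[N+]([O-])c1cccc(CSc2nnc(-c3ccc4c(c3)OCCO4)n2-c2ccccc2)c1`: 30100 nM
- Compound 2 `Clc1ccccc1CSc1nnc(-c2ccc3c(c2)OCCO3)n1-c1ccccc1`: 17400 nM
- Compound 3 `Cc1ccc(CSc2nnc(-c3ccc4c(c3)OCCO4)n2-c2ccccc2)cc1`: 44300 nM

The three compounds share one core and differ only in the aromatic group on a saturated chain carbon bound to a sulfur. Among the measured compounds shown here, compound 2 holds the lowest of the three numbers at 17400 nM, but only one of its two neighbours is clearly separated from it. The data show a 1.7-fold lower number from compound 1 to compound 2 (0.24 log units; within the scatter), whereas they also show a 2.5-fold higher number from compound 2 to compound 3 (0.41 log units; beyond the scatter). The remaining step is a 1.5-fold higher number from compound 1 to compound 3 (0.17 log units; within the scatter).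

The next structure is compound 4 `Fc1ccc(CSc2nnc(-c3ccc4c(c3)OCCO4)n2-c2ccccc2)cc1`, which has not yet been measured. Its change from compound 2 is 4-fluorophenyl in place of 2-chlorophenyl on a saturated chain carbon bound to a sulfur: 4-fluorophenyl in place of 2-chlorophenyl. For the measured compounds named here, no measured compound carries a 4-fluorophenyl group, so the known steps offer only indirect guidance. The closest guide is compound 3, the 4-methylphenyl member, at 44300 nM. Its step from compound 2 is the largest seen, and it points towards a higher number. A small rise is therefore expected in this assay, one that may well stay within the scatter. The expected change is a 1.6-fold higher number from compound 2 to compound 4 (0.21 log units; within the scatter). For compound 4 the estimated value is 28000 nM, with an expected range from 12000 nM to 65000 nM.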

Compound 4, half-maximal inhibitory concentration: > 100000 nM
Compound 4 was reported as a limit; the forecaster's own chance of this, stated with the estimate: 5%; at least 3.5-fold (0.55 log units) between middle value and limit.
By their numbers in this assay, from the lowest: compounds 2, 1 and 3 (each within the scatter of the next, the first and the last beyond it). At a limit, above all of these: compound 4.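

In this assay, compound 4 is recorded as a limit and not as a number: the limit of > 100000 nM in this assay, at which 1 of the 4 values shown sits.

On a saturated chain carbon bound to a sulfur, 4-fluorophenyl in place of 2-chlorophenyl gives an at least 5.7-fold higher number from compound 2 to compound 4 (0.75 log units; beyond the scatter), and the same group also separates compound 4 from the other two members, with an at least 3.3-fold higher number from compound 1 to compound 4 (0.52 log units; beyond the scatter) and an at least 2.2-fold higher number from compound 3 to compound 4 (0.35 log units; beyond the scatter). The earlier compounds had shown only a narrow spread at this place, with a 2.5-fold higher number from compound 2 to compound 3 (0.41 log units; beyond the scatter) as their one step beyond the scatter, whereas this result shows that changing the aromatic group here can move the number further than that, and that fluoro in place of methyl on an aromatic carbon is enough to separate two otherwise identical compounds.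

On these data alone, how far the true value of compound 4 lies past its limit stays unknown, so the size of each of these steps is open at its upper end. A 4-chlorophenyl or a 2-fluorophenyl group on the same carbon would help show whether the halogen or its place on the ring goes with the change, while an unsubstituted phenyl group would give a reference for all four compounds.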